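Swapping the aryl group on the triazole of a kinase-type inhibitor

This account rests on a few compounds, and the source may have more. Where it says the series, first, only, none or still open, it means among the compounds named here.

Compound 2 `COc1cc2c(Oc3ccc(NC(=O)c4nnn(-c5ccccc5C(F)(F)F)c4C(F)(F)F)cc3F)ccnc2cc1OCCCN1CCC(C)CC1` gives 220 nM in a functional assay on A549 cells (Homo sapiens) for cytotoxicity, read by MTT assay, with a stated time of 72 h; on this read-out lower numbers stand for stronger inhibition and higher numbers for weaker inhibition. Compound 1 `COc1cc2c(Oc3ccc(NC(=O)c4nnn(-c5ccc(F)c(F)c5)c4C(F)(F)F)cc3F)ccnc2cc1OCCCN1CCCCC1` gives 160 nM in this assay; the two numbers lie within the usual scatter of each other, so neither compound can be set apart from the other. Compound 3 `COc1cc2c(Oc3ccc(NC(=O)c4nnn(-c5ccc(F)c(F)c5)c4C(F)(F)F)cc3F)ccnc2cc1OCCCN1CCC(C)CC1` carries the change (3,4-difluorophenyl in place of 2-(trifluoromethyl)phenyl on an aromatic nitrogen), the same aryl group that compound 1 already bears. Among the compounds with values here, with no measured step to lean on, the expected step from compound 2 to compound 3 is a 1.2-fold lower number from compound 2 to compound 3 (0.09 log units; within the scatter), nothing beyond the scatter. Compound 3 is therefore estimated at 180 nM in this assay, with a range from 80 nM to 400 nM.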

Compound 3, half-maximal inhibitory concentration: 140 nM
Estimate against measurement, compound 3: 1.3-fold (0.11 log units) above; measured number inside the range.
By their numbers in this assay, from the lowest: compounds 3, 1 and 2 (each within the scatter of the next).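

Compound 2 and compound 3 differ only in the aryl group on the aromatic nitrogen. In this assay, 3,4-difluorophenyl in place of 2-(trifluoromethyl)phenyl gives a 1.6-fold lower number from compound 2 to compound 3 (0.20 log units; within the scatter), so this swap shows no effect that can be told from scatter. Methyl in place of hydrogen on a saturated ring carbon likewise gives a 1.1-fold lower number from compound 1 to compound 3 (0.06 log units; within the scatter), and no measurement is available to explain either step. Still open, on these data alone, is whether a pyridine ring or a 4-methoxyphenyl group on that nitrogen would shift the number beyond the scatter.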